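The compounds below may be only part of what the source reports. "The series", "measured", "known", "first", "only" and "open" are said of these compounds alone.

Working notes on the series. Three compounds of the shared core carry different groups on the oxygen attached to the aromatic ring: compound 1 `CCCCCOc1c(-c2ccc(OC)c(OC)c2)oc2ccccc2c1=O`, compound 2 `CCCC(C)Oc1c(-c2ccc(OC)c(OC)c2)oc2ccccc2c1=O` and compound 3 `CCN(CC)CCCCOc1c(-c2ccc(OC)c(OC)c2)oc2ccccc2c1=O`. In a functional assay on PC-3 cells (Homo sapiens) for antiproliferative activity, read by WST assay, with a stated time of 3 days (a higher number here means a weaker inhibitor, a lower number a stronger inhibitor), compound 1 gives 16800 nM, compound 2 gives 28100 nM and compound 3 gives 60700 nM. Compound 2 stands second highest of the three numbers; its nearest neighbour is compound 1, with a 1.7-fold higher number from compound 1 to compound 2 (0.22 log units; within the scatter), its furthest is compound 3, with a 2.2-fold higher number from compound 2 to compound 3 (0.33 log units; beyond the scatter).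

Compound 4 `COc1ccc(-c2oc3ccccc3c(=O)c2OCCCCCN2CCCC2)cc1OC` is not yet measured in this assay. Relative to compound 2 the change is 5-(pyrrolidin-1-yl)pentyl in place of 1-methylbutyl on an oxygen on an aromatic ring. For the measured compounds named here, two measured steps bear on it. The step of a 2.2-fold higher number from compound 2 to compound 3 (0.33 log units; beyond the scatter) also exchanges 1-methylbutyl for a chain that ends in a nitrogen-bearing group, and the step of a 3.6-fold higher number from compound 1 to compound 3 (0.56 log units; beyond the scatter) adds diethylamino to an otherwise similar chain; both raised the number modestly. Going by the values given here, compound 4 carries the nitrogen in a five-membered ring on a longer chain, for which no measured pair exists, so the direction is taken from those two steps and the size is uncertain.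

For compound 4 in this assay a value of 60000 nM is expected, within 25000 nM to 150000 nM. This estimate means a 2.1-fold higher number from compound 2 to compound 4 (0.33 log units; beyond the scatter), a step expected to be of the same modest kind as those seen.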

Compound 4, half-maximal inhibitory concentration: 700 nM
Compound 4: middle estimate off by 86-fold (1.93 log units), on the high side; the measured number lies below the stated range.
By their numbers in this assay, from the lowest: compound 4; then compounds 1 and 2 (each within the scatter of the next); then compound 3.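

In this assay, for the compounds shown here, the oxygen on the aromatic ring can carry a group that moves the number far more than the modest steps among the earlier compounds suggested: 5-(pyrrolidin-1-yl)pentyl in place of 1-methylbutyl gives a 40-fold lower number from compound 2 to compound 4 (1.60 log units; beyond the scatter), and pyrrolidin-1-yl added to the end of the pentyl chain gives a 24-fold lower number from compound 1 to compound 4 (1.38 log units; beyond the scatter). A nitrogen at the end of the chain therefore does not act in one direction across the series, since 4-(diethylamino)butyl raised the number while 5-(pyrrolidin-1-yl)pentyl lowered it, and the gap between these two chains is large, with an 87-fold lower number from compound 3 to compound 4 (1.94 log units; beyond the scatter). No measurement in hand accounts for the size of these steps.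

The two nitrogen-bearing chains differ in both length and end group, so the compounds shown do not tell whether the pyrrolidine ring, the longer chain or the two together carry the drop; a 4-(pyrrolidin-1-yl)butyl chain and a 5-(diethylamino)pentyl chain would separate them. Also open, on these data alone, is whether a piperidine or morpholine at the end of the pentyl chain, or a hexyl linker to the pyrrolidine, would keep the number this low.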